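The source may hold more compounds than are shown below. What is called first, only, known or untested is meant among the compounds shown, and "the series" means these compounds.

Measured so far:
In an ADME assay on PBMC cells (Homo sapiens) for cytotoxicity, with a stated time of 5 days (a higher number here means a weaker inhibitor, a lower number a stronger inhibitor), compound 1, `O=C(/C=C/c1ccc(N2CCCCC2)cc1)c1ccsc1`, reaches only a limit of the assay, > 100000 nM.
In this assay compound 2, `Cc1csc(C2=NNC(c3ccc(N4CCCCC4)cc3)C2)c1`, gives 24400 nM.

Within the data shown here, compound 2 is the only compound here with an actual number in this assay; the one other value shown is a limit of the assay, (the limit of > 100000 nM in this assay, at which 1 of the 2 values shown sits), so there is no measured step to set the scale of what a single structural change does to this read-out.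

Compound 3, `Clc1ccc(C2=NNC(c3ccc(N4CCCCC4)cc3)C2)s1`, has not yet been measured in this assay. It differs from compound 2 in one place: 5-chlorothiophen-2-yl in place of 4-methylthiophen-2-yl on a carbon with a double bond to nitrogen. Both groups are five-membered aromatic rings of the same size and with the same single hetero atom, so the change is a swap of one small substituent on that ring for another, with nothing gained or lost in hydrogen-bond donors or acceptors.

Without any measured step to lean on, the step from compound 2 to compound 3 in this assay is expected to be a 1.2-fold lower number from compound 2 to compound 3 (0.09 log units; within the scatter), none beyond the usual scatter. Compound 3 is therefore estimated at 20000 nM in this assay, with a range from 7000 nM to 60000 nM.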

Compound 3, half-maximal inhibitory concentration: > 100000 nM
Compound 3 ended at the assay's limit; the forecaster's own chance of this, stated with the estimate: 15%; middle value at least 5.0-fold (0.69 log units) away from the limit.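

Among these compounds, the swap of 4-methylthiophen-2-yl for 5-chlorothiophen-2-yl gives the first measured step in this assay, an at least 4.0-fold higher number from compound 2 to compound 3 (0.61 log units; beyond the scatter). This place on the five-membered ring with 2 nitrogen therefore matters to the read-out, even though the two groups have the same ring and the same counts of heavy atoms, donors and acceptors. The full size of the step cannot be read because compound 3 stands at a limit of the assay and not at a number: the limit of > 100000 nM in this assay, at which 2 of the 3 values shown sit.

Two things change at once in this swap, the substituent on the thiophene and where it sits on that ring, and the compounds shown cannot separate them, whereas a pair with 4-chlorothiophen-2-yl or 5-methylthiophen-2-yl in this place would. Also open, going by these compounds, is how the read-out would respond to a different kind of group here, such as a pyridin-2-yl ring, a phenyl ring or a small cyclopropyl ring.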